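Extending the straight chain of compound 3

The source may report more compounds than this note shows. Statements on the series, on what has been measured and on what is new or still open speak of the compounds shown alone.

Measured in a functional assay on KB cells (Homo sapiens) for cytotoxicity, read by resazurin assay, with a stated time of 3 days; a lower number here means a stronger inhibitor, a higher number a weaker inhibitor:
- compound 1 `CCCCCCCCCCC(=O)NCC(C)(C)CC1=C(O)C(=O)c2ccccc2C1=O`: 17600 nM
- compound 2 `CCCC(C)C(=O)OCC(C)(C)CC1=C(O)C(=O)c2ccccc2C1=O`: 1760 nM
- compound 3 `CCCCCCCC(=O)OCC(C)(C)CC1=C(O)C(=O)c2ccccc2C1=O`: 38300 nM

Of these three, compound 3 carries the highest number and is therefore the weakest inhibitor in this assay. Compound 4 `CCCCCCCCC(=O)OCC(C)(C)CC1=C(O)C(=O)c2ccccc2C1=O` arises from compound 3 through a single change on the straight chain, (methyl in place of hydrogen on a saturated chain carbon, seven bonds along the chain from a carbonyl carbon). This places methyl in place of hydrogen on a saturated chain carbon, seven bonds along the chain from a carbonyl carbon.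

Within the data shown here, only one measured step comes close, a 22-fold higher number from compound 2 to compound 3 (1.34 log units; beyond the scatter), and it is large. That step puts heptyl in place of 1-methylbutyl on a carbonyl carbon, so it changes the chain's shape and does not simply extend it. It therefore says little about the present change. Compound 1, an amide with a longer chain, gives 17600 nM, so a longer chain on that amide does not come with a number above that of compound 3. Among the measured compounds shown here, no measured pair isolates a lengthening of the chain by itself. No clear direction is therefore expected, and the change should stay small. The expected step is a 1.2-fold lower number from compound 3 to compound 4 (0.08 log units; within the scatter), which is not expected to exceed the usual scatter. For compound 4 the estimated value is 32000 nM, with an expected range of 13000 nM to 80000 nM.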

Compound 4, half-maximal inhibitory concentration: 38700 nM
Compound 4: middle estimate off by 1.2-fold (0.08 log units), on the low side; measured number inside the range.
By their numbers in this assay, from the lowest: compound 2; then compound 1; then compounds 3 and 4 (each within the scatter of the next).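

In this assay, among these compounds, methyl in place of hydrogen on a saturated chain carbon, seven bonds along the chain from a carbonyl carbon, gives a 1.0-fold higher number from compound 3 to compound 4 (0.00 log units; within the scatter) and so stays within the scatter, which is the first reading of a lengthening of the straight chain by itself. The large gap to compound 2 holds at this chain length: setting the octyl compound against the 1-methylbutyl compound gives a 22-fold higher number from compound 2 to compound 4 (1.34 log units; beyond the scatter), much like the earlier 22-fold higher number from compound 2 to compound 3 (1.34 log units; beyond the scatter) with heptyl, so among these esters the contrast lies between the 1-methylbutyl compound and the two straight-chain compounds, and extending heptyl to octyl does not alter it. No evidence accompanies these numbers that would account for either the flat step or the large one.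

The compounds shown leave open whether a still longer chain or a shorter one, such as butyl, would read the same way, and whether a hydroxyl group or a carboxylic acid at the end of the chain would move the number. They also leave open how an amide compares with an ester at equal chain length, since compound 1 differs from these esters in more than one place.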